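Replacing the benzothiazolyl sulfide in a cytotoxic amide series

A few compounds are considered here, and "the series" means these few. Any claim that something is new, unique, unknown or untested is made for them only; others in the source may bear on it.

Measured compounds in a functional assay on MCF7 cells (Homo sapiens) for cytotoxicity, read by MTT assay, with a stated time of 24 h, tested at 80 ug/mL; on this read-out higher numbers stand for a stronger effect at the one concentration tested and lower numbers for a weaker effect:
compound 1 `Cc1ccc2oc(SCC(=O)Nc3ccc(-c4nc(-c5ccccc5)c(-c5ccccc5)n4C)cc3)nc2c1` gives 65.1%
compound 2 `Cn1c(-c2ccc(NC(=O)CSc3nc4ccccc4s3)cc2)nc(-c2ccccc2)c1-c1ccccc1` gives 76.6%
compound 3 `Cc1nnc(SCC(=O)Nc2ccc(-c3nc(-c4ccccc4)c(-c4ccccc4)n3C)cc2)s1` gives 85.2%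

Compound 2 stands second highest of the three numbers. Its nearest neighbour is compound 3, with a step of a number 8.6 percentage points higher from compound 2 to compound 3 (within the scatter); the furthest is compound 1, with a step of a number 11.5 percentage points higher from compound 1 to compound 2 (beyond the scatter). Compound 4 `Cn1ccnc1SCC(=O)Nc1ccc(-c2nc(-c3ccccc3)c(-c3ccccc3)n2C)cc1` has not yet been measured. It differs from compound 2 in one place: 1-methyl-1H-imidazol-2-yl in place of 1,3-benzothiazol-2-yl on a sulfur.

Within the data shown here, two measured steps bear on this change, since both swap the group on the sulfur. Moving from the benzothiazolyl group to the small five-membered thiadiazolyl group gave a number 8.6 percentage points higher from compound 2 to compound 3 (within the scatter), and from the benzoxazolyl group to the same thiadiazolyl group gave a number 20.1 percentage points higher from compound 1 to compound 3 (beyond the scatter). The present change likewise replaces the fused ring with a single five-membered ring, so a step of a number 3.4 percentage points higher from compound 2 to compound 4 (within the scatter) is expected, close to the scatter and in the upward direction if any. Compound 4 is therefore expected to give 80%, within a range from 66% to 92%.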

Compound 4, a percentage reported as activity, at one concentration (the size of the read-out at that concentration, not a potency): 64%
Compound 4: middle estimate off by 16 percentage points, on the high side, outside the stated range (below it).
By their numbers in this assay, from the lowest: compounds 4 and 1 (each within the scatter of the next); then compounds 2 and 3 (each within the scatter of the next).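

The single five-membered ring does not by itself carry the higher number in this assay: with 1-methyl-1H-imidazol-2-yl on the sulfur the read-out shows a number 21.2 percentage points lower from compound 3 to compound 4 (beyond the scatter) against the 5-methyl-1,3,4-thiadiazol-2-yl group, and a number 12.6 percentage points lower from compound 2 to compound 4 (beyond the scatter) against the fused 1,3-benzothiazol-2-yl group. Nor do fused and single rings sort into two levels, since a number 1.1 percentage points lower from compound 1 to compound 4 (within the scatter) leaves that single ring level with the fused 5-methyl-1,3-benzoxazol-2-yl group, while the other single ring, in compound 3, stands apart from it. Nothing shown gives a reason for these differences among the groups on the sulfur.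

The compounds shown leave open what the methyl on the imidazolyl ring contributes, a question that an unsubstituted 1H-imidazol-2-yl group on the same sulfur would address. They also leave open whether a 1,2,4-triazol-3-yl group would read nearer to the thiadiazolyl or the imidazolyl group.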